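Adding a Methoxycarbonyl Tetrazole to a Stability Series

The compounds below may be only part of what the source reports. "The series", "measured", "known", "first", "only" and "open" are said of these compounds alone.

Compound 1 `CCCCCCCCc1ccc(OCC(=O)Cn2cnnn2)cc1` carries an unsubstituted tetrazole on the shared core. In an ADME assay on S9 fraction from liver (Rattus norvegicus) for metabolic stability, read by LC-MS, using NADPH, with a stated time of 30 min (on this read-out lower numbers stand for a less stable compound and higher numbers for a more stable compound), compound 1 gives 22%. Among the three measured compounds this is the lowest number: compound 3 `CCCCCCCCc1ccc(OCC(=O)Cn2nnc(-c3ccccn3)n2)cc1` gives 30% in this assay, which lies within the scatter of compound 1, while compound 2 `CCCCCCCCc1ccc(OCC(=O)Cn2nnc(-c3ccccc3)n2)cc1` gives 33% in this assay, which lies beyond it. Both compound 2 and compound 3 carry an aromatic ring on the tetrazole, and swapping one ring for the other gave a number 3 percentage points lower from compound 2 to compound 3 (within the scatter).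

Compound 4 `CCCCCCCCc1ccc(OCC(=O)Cn2nnc(C(=O)OC)n2)cc1` has not yet been measured. It differs from compound 1 in one place: 5-(methoxycarbonyl)-2H-tetrazol-2-yl in place of 1H-tetrazol-1-yl on a saturated chain carbon bound to a carbonyl carbon. Among the measured compounds shown here, the only measured step, from compound 2 to compound 3, exchanges one ring on the tetrazole for another and stayed within the scatter, so it says little about attaching a group where none was. What the numbers do show is that compound 2, with a substituted tetrazole, sits above compound 1, and compound 3 lies within the scatter of compound 1. On that basis a small rise is expected: a number 8 percentage points higher from compound 1 to compound 4 (within the scatter). Compound 4 is therefore estimated at 30% in this assay, within a range from 18% to 42%.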

Compound 4, percent of the compound remaining: < 5%
Compound 4: no number, only a limit (the forecaster's own chance of this, stated with the estimate: 5%); middle value at least 25 percentage points from the limit.
By their numbers in this assay, from the lowest: compounds 1, 3 and 2 (each within the scatter of the next, the first and the last beyond it). At a limit, below all of these: compound 4.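

In this assay compound 4 gives no number, only a limit: the limit of < 5% in this assay, at which 1 of the 4 values shown sits.

Even with that limit, the change from 1H-tetrazol-1-yl to 5-(methoxycarbonyl)-2H-tetrazol-2-yl gives a number at least 17 percentage points lower from compound 1 to compound 4 (beyond the scatter), so a group placed on the tetrazole does not have to leave the compound level with compound 1 or above it, as the aromatic rings of compound 2 and compound 3 do. Methoxycarbonyl in place of pyridin-2-yl on an aromatic carbon gives a number at least 25 percentage points lower from compound 3 to compound 4 (beyond the scatter), and methoxycarbonyl in place of phenyl gives a number at least 28 percentage points lower from compound 2 to compound 4 (beyond the scatter), whereas exchanging the two rings gave only a number 3 percentage points lower from compound 2 to compound 3 (within the scatter), so this position responds strongly to the kind of group it carries, at least when a ring gives way to methoxycarbonyl.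

The compounds shown leave open whether the low reading belongs to methoxycarbonyl alone or would also appear with a methyl group, an amide or a carboxylic acid on the same aromatic carbon. They also leave open how much of the step from the 1H-tetrazol-1-yl compound comes from the tetrazole being joined differently and how much from the added group.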